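Ether-to-amine exchange on the shared core of compound 1

The source may report more compounds than this note shows. Statements on the series, on what has been measured and on what is new or still open speak of the compounds shown alone.

Compound 1 `CCOc1ccc2cc(C(=O)NCCO)c(=O)oc2c1` is one of two measured members of the series. In a functional assay on HCT-116 cells (Homo sapiens) for cytotoxicity, read by MTT assay, with a stated time of 72 h (on this read-out higher numbers stand for weaker inhibition and lower numbers for stronger inhibition), compound 1 reports only a limit, > 100000 nM, so its exact position on the scale is not fixed (the limit of > 100000 nM in this assay, at which 1 of the 2 values shown sits). Compound 2 `O=C(NCCO)c1cc2ccc(OCc3cccc(Br)c3)cc2oc1=O` in this assay gives 30800 nM. Going by the values given here, the single measured step, an at least 3.2-fold lower number from compound 1 to compound 2 (0.51 log units; beyond the scatter), shows that a change on the chain attached to the ring oxygen shifts the number beyond the scatter, though its true size stays open while compound 1 sits at a limit.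

Compound 3 `CCN(CC)c1ccc2cc(C(=O)NCCO)c(=O)oc2c1` differs from compound 1 elsewhere: diethylamino in place of ethoxy on an aromatic carbon. Among the compounds with values here, no measured step concerns this position or this kind of exchange, so the step from compound 1 to compound 2 gives no direct guide; it only shows that the series can move off the limit. The number for compound 3 is therefore expected to lie near that of compound 1, with a modest downward tendency at most, and a renewed limit is quite possible. The expected step is an at least 1.4-fold lower number from compound 1 to compound 3 (0.15 log units; that floor lies within the scatter). Compound 3 is estimated at 70000 nM, in the range 15000 nM to 250000 nM.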

Compound 3, half-maximal inhibitory concentration: > 100000 nM
Compound 3 gave a limit, no number; the forecaster's own chance of this, stated with the estimate: 50%; at least 1.4-fold (0.15 log units) between middle value and limit.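

The step between compound 1 and compound 3 cannot be read, with both compounds reporting only a limit and no number: the limit of > 100000 nM in this assay, at which 2 of the 3 values shown sit.

The compounds shown leave open whether diethylamino in place of ethoxy on an aromatic carbon changes the number at all in this assay, and in which direction.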